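Replacing the thiocarbamate in a fluoropyrimidine series

A few compounds are considered here, and "the series" means these few. Any claim that something is new, unique, unknown or untested is made for them only; others in the source may bear on it.

Compound 1 `Cc1nc(S(C)(=O)=O)ccc1Oc1ncnc(OC2CCN(C(=O)OC3CCC3)CC2)c1F`: 13.6 nM
Compound 2 `Cc1nc(S(C)(=O)=O)ccc1Oc1ncnc(OC2CCN(C(=O)SC(C)C)CC2)c1F`: 6.8 nM
Compound 3 `Cc1nc(S(C)(=O)=O)ccc1Oc1ncnc(OC2CCN(C(=O)SC(C)(C)C)CC2)c1F`: 4.83 nM

In a functional assay on isolated protein for inhibition of Glucose-dependent insulinotropic receptor (Homo sapiens), read by HTRF and cAMP accumulation (on this read-out higher numbers stand for an effect only at larger amounts of compound and lower numbers for an effect already at smaller amounts), compound 3 gives the lowest of the three numbers. Its lead over compound 2 is small, a 1.4-fold lower number from compound 2 to compound 3 (0.15 log units; within the scatter), whereas against compound 1 it is clearer, a 2.8-fold lower number from compound 1 to compound 3 (0.45 log units; beyond the scatter); the change from compound 1 to compound 2 was a 2.0-fold lower number from compound 1 to compound 2 (0.30 log units; within the scatter).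

Compound 4 `Cc1nc(S(C)(=O)=O)ccc1Oc1ncnc(OC2CCN(C(=O)c3noc(C(C)(C)F)n3)CC2)c1F` differs from compound 3 at the carbonyl carbon whose other neighbour is the amide-type nitrogen in a ring: a group of 9 heavy atoms (5 carbon, 2 nitrogen, 1 oxygen, 1 fluorine; one five-membered aromatic ring with 3 hetero atoms) in place of a group of 5 heavy atoms (4 carbon, 1 sulfur; no ring), on a carbonyl carbon

Among the compounds with values here, none of the measured steps exchanges the group on that carbonyl carbon for a ring. The steps that do touch this position, from compound 1 to compound 3 and from compound 1 to compound 2, show that a cyclobutyloxy group and the two sulfanyl groups all give numbers within a narrow span in this assay. On that basis a step of modest size at most is expected in this assay, direction uncertain, with a step of a 1.4-fold higher number from compound 3 to compound 4 (0.16 log units; within the scatter) taken as the central expectation. Compound 4 is therefore estimated at 7 nM, with a range from 1.5 nM to 30 nM.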

Compound 4, half-maximal effective concentration: 14 nM
Compound 4: middle estimate off by 2.0-fold (0.30 log units), on the low side; the measured number falls inside the stated range.
By their numbers in this assay, from the lowest: compounds 3, 2, 1 and 4 (each within the scatter of the next, the first and the last beyond it).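

In this assay, a five-membered aromatic ring with 3 hetero atoms proves acceptable on the carbonyl carbon whose other neighbour is the amide-type nitrogen in a ring, so this position is not confined to groups of the sulfanyl or cyclobutyloxy type. The ring-bearing group does cost something against both sulfanyl groups, with a 2.9-fold higher number from compound 3 to compound 4 (0.46 log units; beyond the scatter) and a 2.1-fold higher number from compound 2 to compound 4 (0.31 log units; beyond the scatter) as modest steps, so the sulfanyl groups of compound 2 and compound 3 remain ahead of it. Against the cyclobutyloxy group there is no such cost, as a 1.0-fold higher number from compound 1 to compound 4 (0.01 log units; within the scatter) leaves the two compounds indistinguishable, which places the larger group with more hydrogen-bond acceptors level with an ether-linked carbocycle, though still short of the sulfanyl pair.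

No supporting measurement is available to explain these steps.

What the compounds shown leave open is which part of the entering group sets its number, the ring itself or the fluorine-bearing carbon on it. The same ring carrying tert-butyl or cyclopropyl in place of that carbon would separate the two, and a plain phenyl ring on the carbonyl carbon would show whether the hetero atoms matter at all.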